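The compounds below may be only part of what the source reports. "The series", "measured", "known", "first", "only" and "open" are said of these compounds alone.

Three compounds share one core and differ only in the aryl group on the sulfonyl sulfur. Compound 1 `O=C(NCc1ccc(CNS(=O)(=O)c2ccc([N+](=O)[O-])cc2)cc1)c1ccc(CNc2ncccn2)cc1` carries 4-nitrophenyl there, compound 2 `O=C(NCc1ccc(CNS(=O)(=O)c2cccc(Cl)c2)cc1)c1ccc(CNc2ncccn2)cc1` carries 3-chlorophenyl and compound 3 `O=C(NCc1ccc(CNS(=O)(=O)c2ccccc2Cl)cc1)c1ccc(CNc2ncccn2)cc1` carries 2-chlorophenyl. In an assay on MDA-MB-231 cells for binding affinity to C-X-C chemokine receptor type 4 (Homo sapiens), read by microscopy, with stated times of 10 min and 30 min (a lower number here means that less compound is needed, a higher number that more compound is needed for the effect), compound 1 gives 1000 nM, compound 2 gives 1 nM and compound 3 gives 1000 nM. Compound 3 thus stands level with compound 1, the two together being the highest numbers of the three, and far from compound 2, since a 1000-fold higher number from compound 2 to compound 3 (3.00 log units; beyond the scatter).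

Compound 4 `O=C(NCc1ccc(CNS(=O)(=O)c2cccc(F)c2)cc1)c1ccc(CNc2ncccn2)cc1` is the next step: 3-fluorophenyl in place of 2-chlorophenyl on a sulfonyl sulfur. The measured steps that bear on it are a 1000-fold lower number from compound 1 to compound 2 (3.00 log units; beyond the scatter), a large step, and no change at the digits printed from compound 1 to compound 3 (within the scatter). Both say that 3-chlorophenyl stands far apart from the other two groups, and compound 4 brings in 3-fluorophenyl, a group named with the same number. Nothing here compares fluorine with chlorine, so the estimate is uncertain. A large drop is expected: a 100-fold lower number from compound 3 to compound 4 (2.00 log units; beyond the scatter). In this assay compound 4 is estimated at 10 nM, with a range from 1 nM to 300 nM.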

Compound 4, effective concentration (reported as EC, without a stated level of effect): 1000 nM
Compound 4: middle estimate off by 100-fold (2.00 log units), on the low side, and the stated range ends below it.
By their numbers in this assay, from the lowest: compound 2; then compounds 1, 3 and 4 (each within the scatter of the next).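

Fluoro in place of chloro on an aromatic carbon brings a 1000-fold higher number from compound 2 to compound 4 (3.00 log units; beyond the scatter) in this assay and shows that the low number of compound 2 does not survive this single atom change. Set against the other groups, 3-fluorophenyl gives no change at the digits printed from compound 3 to compound 4 (within the scatter) and also no change at the digits printed from compound 1 to compound 4 (within the scatter) on this sulfonyl sulfur. Of the four aryl groups, only 3-chlorophenyl stands apart, and the shared number in the name does not carry its low value over to 3-fluorophenyl.

The compounds shown leave open whether the low number depends on chlorine itself, a question that 3-bromophenyl or 3-methylphenyl at this place could address. Nothing available explains the sharp split between the two halogen-bearing groups.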